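This account rests on a few compounds, and the source may have more. Where it says the series, first, only, none or still open, it means among the compounds named here.

Within the data shown here, compound 1 `O=C(CN1CN(c2ccccc2)C2(CCN(C(=O)c3ccc(C4CCCCC4)cc3)CC2)C1=O)N1CCC(CO)CC1` stands lowest of the two numbers measured so far in an assay on HEK293 cells for displacement of a labelled ligand from NPC1-like intracellular cholesterol transporter 1 (Homo sapiens) (a higher number here means a weaker inhibitor, a lower number a stronger inhibitor), giving 1100 nM. Compound 2 `CCc1nn(CC)c(C2CCN(C(=O)CN3CN(c4ccccc4)C4(CCN(C(=O)c5ccc(C(C)(C)C)cc5)CC4)C3=O)CC2)c1C` gives 2500 nM in this assay, a gap that lies beyond the usual scatter. Compound 3 `CCOC(=O)C1CCCN(C(=O)CN2CN(c3ccccc3)C3(CCN(C(=O)c4ccc(C5CCCCC5)cc4)CC3)C2=O)C1` has not yet been measured; it differs from compound 1 in one place: 3-(ethoxycarbonyl)piperidin-1-yl in place of 4-(hydroxymethyl)piperidin-1-yl on a carbonyl carbon. Among the measured compounds shown here, no measured pair shows this change, so nothing is known of its effect. A small loss is expected, a 1.4-fold higher number from compound 1 to compound 3 (0.13 log units; within the scatter), close to the edge of the scatter. Compound 3 is estimated to give 1500 nM in this assay, with a range from 500 nM to 4500 nM.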

Compound 3, half-maximal inhibitory concentration: 4200 nM
For compound 3 the middle estimate is 2.8-fold (0.45 log units) below the measured one, within the range that was stated.
By their numbers in this assay, from the lowest: compound 1; then compounds 2 and 3 (each within the scatter of the next).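

In this assay, the group on this carbonyl carbon proves able to shift the result: 3-(ethoxycarbonyl)piperidin-1-yl in place of 4-(hydroxymethyl)piperidin-1-yl gives a 3.8-fold higher number from compound 1 to compound 3 (0.58 log units; beyond the scatter), a modest loss beyond the scatter. With the rest of the molecule unchanged, the piperidine substituents at this position are not interchangeable. No available measurement bears on the reason for this loss. The compounds shown leave open whether the substituent's ring place or the exchange of hydroxymethyl for ethoxycarbonyl accounts for the step, and how a carboxylic acid on that piperidine would compare.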